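A Thiocarbonyl Amine Swap Examined at the Assay Limit

The compounds below may be only part of what the source reports. "The series", "measured", "known", "first", "only" and "open" are said of these compounds alone.

Compound 1 `CC(C)N(C(=S)SCc1cc(=O)c2ccc(Cl)cc2o1)C(C)C`: in a functional assay on MCF7 cells (Homo sapiens) for antiproliferative activity, read by MTT assay, with a stated time of 72 h (on this read-out higher numbers stand for weaker inhibition and lower numbers for stronger inhibition), compound 1 gives > 25000 nM, a limit of the assay rather than a number.
Compound 2 `O=c1cc(CSC(=S)N2CCOCC2)oc2cc(Cl)ccc12`: in this assay compound 2 gives > 25000 nM, again a limit and not a number.
Going by the values given here, compound 3 `CC(C)N(C(=S)SCc1cc(=O)c2ccccc2o1)C(C)C`: in this assay compound 3 gives 31700 nM, the only number among the three.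

The change from compound 1 to compound 2 is morpholin-4-yl in place of diisopropylamino on a thiocarbonyl carbon. Its step is a step that the two limits leave unreadable from compound 1 to compound 2 because of the limit of > 25000 nM in this assay, at which 2 of the 3 values shown sit. The two cores differ by hydrogen in place of chloro on an aromatic carbon, and that step is a step that the limit leaves unreadable from compound 1 to compound 3, again unreadable owing to the limit.

Compound 4 `O=c1cc(CSC(=S)N2CCOCC2)oc2ccccc12` has not been measured. It differs from compound 3 by morpholin-4-yl in place of diisopropylamino on a thiocarbonyl carbon, the same change as that from compound 1 to compound 2, made on the same kind of place. Among the compounds with values here, since compound 1 and compound 2 both sit at a limit, the measured pair gives no readable size for this change, and compound 3 is the only number available as a starting point.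

Compound 4 is therefore expected to stay close to its parent, a step of a 1.3-fold higher number from compound 3 to compound 4 (0.10 log units; within the scatter), because compound 3 gives 31700 nM and the same change in compound 1 gave a step that the two limits leave unreadable from compound 1 to compound 2, which rules nothing out. Compound 4 is estimated at 40000 nM, with a likely range from 15000 nM to 120000 nM, and a report of only a limit rather than a number is about as likely as not.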

Compound 4, half-maximal inhibitory concentration: 21000 nM
Compound 4: middle estimate off by 1.9-fold (0.28 log units), on the high side; the range from low to high includes it.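

In this assay, morpholin-4-yl in place of diisopropylamino on a thiocarbonyl carbon can now be sized on the core without chloro, where it gives a 1.5-fold lower number from compound 3 to compound 4 (0.18 log units; within the scatter), so on this core the change leaves the read-out where it was, as far as the usual scatter of repeats can tell. Replacing chloro with hydrogen on an aromatic carbon, with morpholin-4-yl held in place, gives an at least 1.1-fold lower number from compound 2 to compound 4 (0.07 log units; that floor lies within the scatter), which is a floor rather than a measured size. This does not show that the amine change carries from one core to the other, because the same change on the chloro core and the step from compound 1 to compound 3 both cannot be read: the limit of > 25000 nM in this assay, at which 2 of the 4 values shown sit.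

The compounds shown leave open whether any other amine on the thiocarbonyl carbon, such as piperidin-1-yl or dimethylamino, would move the read-out beyond the scatter on either core. They also leave open whether a group other than chloro on the aromatic carbon, such as fluoro or methoxy, would bring a value into the readable range, where the amine change could be compared between two cores.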